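Cyclopropyl in place of trifluoromethyl on the shared core

The source may report more compounds than this note shows. Statements on the series, on what has been measured and on what is new or still open speak of the compounds shown alone.

Compound 2 `Cc1cc(C)c(-c2csc(NC(=O)/C=C/c3ccc(C(F)(F)F)cc3)n2)c(C)c1` carries a trifluoromethyl group on an aromatic carbon of its six-membered aromatic ring of carbon only, para to a large group. In a functional assay on MCF7 cells (Homo sapiens) for inhibition, read by MTT assay, with a stated time of 96 h (a lower number here means a stronger inhibitor, a higher number a weaker inhibitor), compound 2 gives only a limit, > 30000 nM. Compound 1 `Cc1cc(C)c(-c2csc(NC(=O)/C=C/c3ccc(C(C)(C)C)cc3)n2)c(C)c1` carries tert-butyl where compound 2 carries trifluoromethyl. In this assay compound 1 likewise gives only a limit, > 30000 nM. Among the compounds with values here, the step that the two limits leave unreadable from compound 1 to compound 2 is therefore unreadable, and the only evidence on the measured steps is the limit of > 30000 nM in this assay, at which 2 of the 2 values shown sit. Compound 3 `Cc1cc(C)c(-c2csc(NC(=O)/C=C/c3ccc(C4CC4)cc3)n2)c(C)c1` differs from compound 2 by cyclopropyl in place of trifluoromethyl on an aromatic carbon. Within the data shown here, no measured step bears on this change in a readable size, so no step beyond the scatter in either direction can be expected. The expected step is a number no higher from compound 2 to compound 3 (the limit leaves the size open). Compound 3 is therefore estimated to give 30000 nM in this assay, with a range from 10000 nM to 100000 nM, most likely reported again only as a limit.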

Compound 3, half-maximal inhibitory concentration: 7760 nM
Compound 3: middle estimate off by 3.9-fold (0.59 log units), on the high side; measured number below the stated range.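

In this assay, within the data shown here, this place on the aromatic carbon, para to a large group, now gives a readable change for the first time: cyclopropyl in place of trifluoromethyl gives an at least 3.8-fold lower number from compound 2 to compound 3 (0.58 log units; beyond the scatter). Cyclopropyl in place of tert-butyl at the same place gives an at least 3.8-fold lower number from compound 1 to compound 3 (0.58 log units; beyond the scatter), so compound 3 is the only one of the three with a number rather than a limit. Both steps are therefore minimum sizes, and the step between compound 1 and compound 2 cannot be read: the limit of > 30000 nM in this assay, at which 2 of the 3 values shown sit.

The compounds shown leave open how a methyl, a cyclobutyl, a methoxy or an amine at this place would read in this assay. They also leave open how large the true gaps from compound 1 and compound 2 to compound 3 are.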